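Piperidine to Piperazine: Stability in Rat Liver Microsomes

The source may hold more compounds than are shown below. What is called first, only, known or untested is meant among the compounds shown, and "the series" means these compounds.

Measured compounds:
Compound 1: `c1ccc2c(c1)CN[C@@H](CN(CC[C@H]1CCCNC1)[C@H]1CCCc3cccnc31)C2` — 55%
Compound 2: `c1cnc(CN(CCCN2CCNCC2)[C@H]2CCCc3cccnc32)nc1` — 68%

Of the compounds shown here, two have been tested in an ADME assay on microsomes from liver (Rattus norvegicus) for metabolic stability, read by LC-MS, with a stated time of 10 min, tested at 0.5 uM; on this read-out lower numbers stand for a less stable compound and higher numbers for a more stable compound. Compound 1 gives the lower of the two numbers; compound 2 lies higher by a gap that exceeds the usual scatter of repeated runs, so compound 2 is the more stable of the pair. The two differ in more than one place, so the gap cannot be tied to a single change.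

Compound 3, `c1ccc2c(c1)CN[C@@H](CN(CCN1CCNCC1)[C@H]1CCCc3cccnc31)C2`, has not yet been measured. It differs from compound 1 in one place: piperazin-1-yl in place of piperidin-3-yl on a saturated chain carbon, two bonds along the chain from an amine nitrogen. Going by the values given here, the new ring also appears in compound 2, the more stable compound, though compound 2 carries it on a different chain and with another group on the amine nitrogen, so no direct step is available.

On that basis a small upward step from compound 1 is expected, a number 7 percentage points higher from compound 1 to compound 3 (within the scatter), one that may not clearly exceed the scatter. Compound 3 is therefore estimated at 62%, with a range from 48% to 76%.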

Compound 3, percent of the compound remaining: 62%
Beside the measured number, compound 3's estimate shows no gap at the digits printed; the measured number falls inside the stated range.
By their numbers in this assay, from the lowest: compounds 1, 3 and 2 (each within the scatter of the next, the first and the last beyond it).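

Going by these compounds alone, this pair gives the first direct reading at this place, on a saturated chain carbon, two bonds along the chain from an amine nitrogen: with the rest of compound 1 held fixed, piperazin-1-yl in place of piperidin-3-yl gives a number 7 percentage points higher from compound 1 to compound 3 (within the scatter) in this assay. The ring that enters holds 2 hetero atoms where the ring that leaves holds 1, and the defined stereocentre of piperidin-3-yl is gone, yet this read-out does not clearly separate the two compounds. No measurement shown here accounts for the size of this step.

Still open, as far as these compounds go, is whether another group at this place, such as morpholine, which has an oxygen where piperazine has its second ring nitrogen, or an open-chain dimethylamino group, would give a step beyond the usual scatter in this assay. Also open, from the compounds shown here alone, is whether the same exchange of piperidin-3-yl for piperazin-1-yl would read alike on a core other than that of compound 1.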